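Free ring amine in place of the protected amine

This account rests on a few compounds, and the source may have more. Where it says the series, first, only, none or still open, it means among the compounds named here.

Compound 2, `CC(C)(C)OC(=O)N1CCN(C(=S)SCc2cn(Cc3ccc(Cl)cc3)nn2)CC1`, carries on its shared core a six-membered non-aromatic ring with two nitrogen atoms, one of which is capped by a tert-butoxycarbonyl group. In a functional assay on PC-3 cells (Homo sapiens) for inhibition, read by MTT assay, with a stated time of 72 h (on this read-out lower numbers stand for stronger inhibition and higher numbers for weaker inhibition), compound 2 reaches only a limit of the measurement, > 128000 nM. Its two neighbours differ from it only in the group on the aromatic nitrogen. Compound 1, `CC(C)(C)OC(=O)N1CCN(C(=S)SCc2cn(-c3ccccc3F)nn2)CC1`, gives in this assay a limit as well, > 128000 nM. Compound 3, `Cc1ccc(-n2cc(CSC(=S)N3CCN(C(=O)OC(C)(C)C)CC3)nn2)cc1`, likewise gives a limit in this assay, > 128000 nM. The steps among the three, a step that the two limits leave unreadable from compound 1 to compound 2, a step that the two limits leave unreadable from compound 1 to compound 3 and a step that the two limits leave unreadable from compound 2 to compound 3, cannot be read because of the limit of > 128000 nM in this assay, at which 3 of the 3 values shown sit. Compound 4, `S=C(SCc1cn(Cc2ccc(Cl)cc2)nn1)N1CCNCC1`, is compound 2 without its cap: hydrogen in place of tert-butoxycarbonyl on an amine nitrogen in a ring. Among the compounds with values here, none of the measured steps touches the amine nitrogen in the ring, so no measured step bears on this change, and the three unreadable steps give no size to expect for it in either direction. Compound 4 is therefore expected to stay near the limit, with an estimate of 150000 nM in this assay and a range from 30000 nM to 600000 nM. The step this estimate means, a step that the limit leaves unreadable from compound 2 to compound 4, is expected to be small.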

Compound 4, half-maximal inhibitory concentration: > 128000 nM
Compound 4 gave a limit, no number; the forecaster's own chance of this, stated with the estimate: 70%; the middle value does not contradict the limit.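

Within the data shown here, compound 4 gives only a limit in this assay, > 128000 nM, so the step from compound 2 cannot be read any more than the earlier ones, because no compound has a number here: the limit of > 128000 nM in this assay, at which 4 of the 4 values shown sit. The compounds shown leave open whether either the group on the aromatic nitrogen or the tert-butoxycarbonyl cap affects inhibition in this assay, and by how much.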